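The source may hold more compounds than are shown below. What is called first, only, known or untested is meant among the compounds shown, and "the series" means these compounds.

Working notes on the series. Compound 1 `O=S(=O)(Nc1cccc2cc[nH]c12)c1ccc(Cl)cc1` is the reference; in a functional assay on MC-38 cells (Mus musculus) for antiproliferative activity, read by colorimetric assay and MTT assay (on this read-out lower numbers stand for stronger inhibition and higher numbers for weaker inhibition), compound 1 gives 7 ug/mL. Compound 2 `O=S(=O)(Nc1ccc(Cl)c2cc[nH]c12)c1ccc(Cl)cc1` carries chloro in place of hydrogen on an aromatic carbon and in this assay compound 2 gives 0.66 ug/mL, the step being an 11-fold lower number from compound 1 to compound 2 (1.03 log units; beyond the scatter). Compound 3 `N#Cc1ccc(S(=O)(=O)Nc2ccc(Cl)c3cc[nH]c23)cc1` has cyano in place of chloro on an aromatic carbon, and in this assay compound 3 gives 0.22 ug/mL, a step of a 3.0-fold lower number from compound 2 to compound 3 (0.48 log units; beyond the scatter). Compound 3 thus holds the lowest number of the three measured, with both steps beyond the scatter.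

Compound 4 `N#Cc1ccc(S(=O)(=O)Nc2ccc(Cl)c3c(Cl)c[nH]c23)cc1`, not yet measured, differs from compound 3 by chloro in place of hydrogen on an aromatic carbon. Going by the values given here, this is the same kind of change as the one from compound 1 to compound 2, but not the same: there the place was on a six-membered aromatic ring of carbon only, ortho to a fused ring, meta to a fused ring, para to a large group; here it is on a five-membered aromatic ring with one nitrogen, two ring bonds from the ring nitrogen. The difference between the cores of compound 1 and compound 3 is not broken down here. Among the compounds with values here, the change occurs twice in all, with only one instance measured. Because the earlier step of an 11-fold lower number from compound 1 to compound 2 (1.03 log units; beyond the scatter) was large but sat at a different place, a smaller step is expected from compound 3 to compound 4, estimated at a 1.8-fold lower number from compound 3 to compound 4 (0.26 log units; within the scatter). Compound 4 is expected to give about 0.12 ug/mL in this assay, estimated between 0.04 ug/mL and 0.4 ug/mL.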

Compound 4, half-maximal inhibitory concentration: 0.12 ug/mL
Compound 4: the middle estimate sits on the measured number at the digits printed; low and high end bracket the measured number.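

In this assay the new step is a 1.8-fold lower number from compound 3 to compound 4 (0.26 log units; within the scatter), so this chloro does not separate compound 4 from compound 3. Chloro in place of hydrogen on an aromatic carbon therefore does not carry its earlier size over to this core and place, and the two instances differ: the same change on two cores in this assay, an 11-fold lower number (1.03 log units; beyond the scatter) from compound 1 to compound 2 and a 1.8-fold lower number (0.26 log units; within the scatter) from compound 3 to compound 4, 5.8-fold (0.76 log units) apart, beyond the scatter of two such steps. This does not show whether the core or the place accounts for that gap, as the two instances differ in both, with the earlier chloro at a different place and the later one on the five-membered aromatic ring with 1 nitrogen, and two instances give no general rule for the series.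

On these data alone, it remains open what chloro at this same place would do on the core of compound 1, which would separate the effect of the core from that of the place. Also open, as far as these compounds go, is how other groups at this place, such as methyl, bromo, an amine or a carboxylic acid, would compare with hydrogen and chloro in this assay.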